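Working notes: from compound 3 to compound 4

The compounds below may be only part of what the source reports. "The series", "measured", "known", "first", "only" and "open" are said of these compounds alone.

Measured in a functional assay on HepG2 cells (Homo sapiens) for inhibition, read by MTT assay, with a stated time of 48 h; on this read-out lower numbers stand for stronger inhibition and higher numbers for weaker inhibition:
compound 1 `Fc1ccc(/C=N/Nc2nc(-c3ccc(C(F)(F)F)cc3)cs2)cc1F`: 14500 nM
compound 2 `Fc1ccc(/C=N/Nc2nc(-c3cc(C(F)(F)F)cc(C(F)(F)F)c3)cs2)cc1F`: 16700 nM
compound 3 `COc1cc(/C=N/Nc2nc(-c3ccc(Br)cc3)cs2)cc(Br)c1OC`: 64600 nM

Compound 3 gives the highest number of the three. Its nearest neighbour is compound 2, whose number lies beyond the scatter below it; compound 1 lies further off still, also beyond the scatter. Compound 4 `COc1cc(/C=N/Nc2nc(-c3cccc(Br)c3)cs2)cc(Br)c1OC` keeps every atom of compound 3 but joins them differently: 3-bromophenyl in place of 4-bromophenyl on an aromatic carbon. No measured pair in the set differs only in this way, so the step has no precedent among these compounds. The expectation is a step from compound 3 to compound 4 of a 1.1-fold lower number from compound 3 to compound 4 (0.03 log units; within the scatter), that is, none beyond the scatter in either direction. Compound 4 is estimated at 60000 nM in this assay, with a range from 25000 nM to 150000 nM.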

Compound 4, half-maximal inhibitory concentration: 66200 nM
The estimate for compound 4 lay 1.1-fold (0.04 log units) below the measured number, within the range that was stated.
By their numbers in this assay, from the lowest: compounds 1 and 2 (each within the scatter of the next); then compounds 3 and 4 (each within the scatter of the next).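

In this assay, 3-bromophenyl in place of 4-bromophenyl on the aromatic carbon next to the ring nitrogen gives a 1.0-fold higher number from compound 3 to compound 4 (0.01 log units; within the scatter). For the compounds shown here, this is the first one-place comparison, and at this position it separates the two bromophenyl isomers by no more than the scatter. No available data address why the two compounds read alike.

Going by these compounds, it remains open whether a group other than bromine on this phenyl ring, such as an amine or a carboxylic acid, would read differently from compound 3. On these data alone, it is also open whether the same exchange would read alike on another core.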